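The compounds below may be only part of what the source reports. "The series", "measured", "known", "first", "only" and "open" are said of these compounds alone.

Working notes on the series, read in a functional assay on SW1573 cells (Homo sapiens) for antiproliferative activity, read by sulforhodamine B assay, with a stated time of 48 h; a lower number here means a stronger inhibitor of growth, a higher number a weaker inhibitor of growth. Compound 1 `CC(C)(C)[Si](C)(C)OC[C@H]1OCCC[C@H]1O[Si](C)(C)C(C)(C)C` gives > 100000 nM, which is a limit of the assay and not a number. Compound 2 `CC(C)(C)[Si](C)(C)O[C@@H]1CCCO[C@@H]1CO` gives > 100000 nM, again only a limit. Compound 3 `O=C(/C=C/[C@H]1OCCC[C@H]1O)OCc1ccccc1` gives > 100000 nM, also a limit. Within the data shown here, compound 2 thus has no measured number of its own, and the whole series so far stands at the limit of > 100000 nM in this assay, at which 3 of the 3 values shown sit.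

The next structure is compound 4 `COC(=O)/C=C\[C@H]1OCCC[C@H]1O[Si](C)(C)C(C)(C)C`. The change is 2-(methoxycarbonyl)ethenyl in place of hydroxymethyl on a saturated ring carbon, next to the ring oxygen. The group entering has no hydrogen-bond donor, while the one leaving has one.

Among the measured compounds shown here, the only measured step that bears on this is a step that the two limits leave unreadable from compound 1 to compound 2. It provides no size to carry over, and it lies on an oxygen rather than on the ring carbon changed here. For the measured compounds named here, no measured compound therefore sets the size of the new step. A reading at the limit remains about as likely as not in this assay, and any number reported would be expected to show only weak growth inhibition. The expected change is an at least 1.4-fold lower number from compound 2 to compound 4 (0.15 log units; that floor lies within the scatter), an estimate anchored on a limit and not on a number. For compound 4 the estimated value is 70000 nM, with an expected range from 25000 nM to 100000 nM.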

Compound 4, concentration for 50% growth inhibition: 6300 nM
For compound 4 the middle estimate is 11-fold (1.05 log units) above the measured one; the whole stated range lies above it.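

In this assay, among these compounds, 2-(methoxycarbonyl)ethenyl in place of hydroxymethyl on the saturated ring carbon next to the ring oxygen gives an at least 15-fold lower number from compound 2 to compound 4 (1.20 log units; beyond the scatter), the first step with a readable size. Among the compounds shown here, compound 4 is also the first compound with a measured number, 6300 nM. A change at this ring carbon can therefore move the series off the limit that holds the other compounds: the limit of > 100000 nM in this assay, at which 3 of the 4 values shown sit. The value of compound 2 is a limit and not a number, so the printed size of the step is only a floor.

The compounds shown do not separate the contribution of the methyl ester from that of the ethenyl link, which a carboxylic acid or a primary amide at the end of the chain, or a saturated chain in place of the ethenyl, would address. As far as these compounds go, the step from compound 1 to compound 2 cannot be read, so the part played by the group on the ring atom next to this ring carbon also stays open, and a free hydroxyl there alongside the 2-(methoxycarbonyl)ethenyl group would test it.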